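The compounds below may be only part of what the source reports. "The series", "measured", "known", "first", "only" and "open" are said of these compounds alone.

Compound 1 `Cc1c(Cc2ccccc2)c(=O)oc2cc(OCCOc3no[n+]([O-])c3S(=O)(=O)c3ccccc3)ccc12`: 16.3 nM
Compound 2 `COc1cc(OCCOc2no[n+]([O-])c2S(=O)(=O)c2ccccc2)ccc1C(=O)/C=C/c1ccccc1`: 18 nM
Compound 3 `Cc1c(Cc2ccc(F)cc2)c(=O)oc2cc(OCCOc3no[n+]([O-])c3S(=O)(=O)c3ccccc3)ccc12`: 5.1 nM
Compound 4 `CNS(=O)(=O)Nc1cccc(Cc2c(C)c3ccc(OCCOc4no[n+]([O-])c4S(=O)(=O)c4ccccc4)cc3oc2=O)c1`: not yet measured

In a functional assay on NCI/ADR-RES cells (Homo sapiens) for antiproliferative activity, read by MTT assay, with a stated time of 48 h (a higher number here means a weaker inhibitor, a lower number a stronger inhibitor), compound 3 has the lowest number of the three, at 5.1 nM. Compound 4 differs from it by 3-((methylsulfamoyl)amino)phenyl in place of 4-fluorophenyl on a saturated chain carbon bound to an aromatic carbon. For the measured compounds named here, one measured step bears on this change: a 3.2-fold lower number from compound 1 to compound 3 (0.50 log units; beyond the scatter), a modest one, for fluoro in place of hydrogen on an aromatic carbon. Going by the values given here, compound 4 has no such fluoro, and no measured compound carries the entering group. A modest loss is therefore expected, about the size of that step reversed. The expected change is a 2.5-fold higher number from compound 3 to compound 4 (0.41 log units; beyond the scatter). For compound 4 the estimated value is 13 nM, with an expected range of 4 nM to 45 nM.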

Compound 4, half-maximal inhibitory concentration: 50.1 nM
Estimate against measurement, compound 4: 3.9-fold (0.59 log units) below; measured number above the stated range.
By their numbers in this assay, from the lowest: compound 3; then compounds 1 and 2 (each within the scatter of the next); then compound 4.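

In this assay, 3-((methylsulfamoyl)amino)phenyl in place of 4-fluorophenyl gives a 9.8-fold higher number from compound 3 to compound 4 (0.99 log units; beyond the scatter) on a saturated chain carbon bound to an aromatic carbon. The rise is not just the loss of fluoro: (methylsulfamoyl)amino in place of hydrogen gives a 3.1-fold higher number from compound 1 to compound 4 (0.49 log units; beyond the scatter) by itself, so substitution on this aromatic ring has now moved the number in both directions. No available evidence accounts for this rise. From the compounds shown here alone, it remains open whether the loss follows the (methylsulfamoyl)amino group as a whole or its place on the ring. A plain amine or a carboxylic acid on this ring would help separate these possibilities.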